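From trifluoromethyl to nitro on the shared core

The source may report more compounds than this note shows. Statements on the series, on what has been measured and on what is new or still open speak of the compounds shown alone.

Of the compounds shown here, three built on a shared core have been tested in an ADME assay on Vero cells (Chlorocebus sabaeus) for cytotoxicity; on this read-out higher numbers stand for lower toxicity in this test and lower numbers for higher toxicity in this test. Compound 1 `COc1cc(OC)cc(-c2nc3cc(C(F)(F)F)ccc3[nH]2)c1` gives only a limit of the assay, > 100000 nM, and not a number. Compound 2 `COc1ccc(-c2nc3cc(C(F)(F)F)ccc3[nH]2)c(OC)c1OC` gives 70000 nM, the higher of the two actual numbers. Compound 3 `O=[N+]([O-])c1ccc(-c2nc3cc(C(F)(F)F)ccc3[nH]2)c([N+](=O)[O-])c1` gives 25000 nM, which lies below compound 2 by more than the usual scatter of repeated measurements.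

Compound 4 `COc1ccc(-c2nc3cc([N+](=O)[O-])ccc3[nH]2)c(OC)c1OC` has not yet been measured. It differs from compound 2 in one place, with nitro in place of trifluoromethyl on an aromatic carbon. For the measured compounds named here, no tested pair shows this exchange, so the evidence is thin. Going by the values given here, the nearest guide is compound 3, the only tested compound carrying nitro groups, at 25000 nM. No step beyond the scatter is expected in this assay, although any drift seems more likely to run toward lower numbers. The estimated step is a 1.8-fold lower number from compound 2 to compound 4 (0.24 log units; within the scatter). The estimate for compound 4 is 40000 nM, with an expected range from 13000 nM to 100000 nM.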

Compound 4, half-maximal cytotoxic concentration: > 100000 nM
Compound 4 was reported as a limit; the forecaster's own chance of this, stated with the estimate: 15%; middle value at least 2.5-fold (0.39 log units) away from the limit.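

For the compounds shown here, this is the first direct look at exchanging trifluoromethyl for nitro at this aromatic carbon of the shared core, and in this assay it gives an at least 1.4-fold higher number from compound 2 to compound 4 (0.15 log units; that floor lies within the scatter). With the rest of the molecule held constant, nitro at this position therefore brings no fall toward lower numbers, which means no sign of greater toxicity in this test. Compound 4 gives only a limit and not a number, so the true size of the step cannot be read, and a rise beyond the scatter can be neither confirmed nor ruled out: the limit of > 100000 nM in this assay, at which 2 of the 4 values shown sit.

From the compounds shown here alone, it remains open whether other groups at this same carbon, such as an amine or a carboxylic acid, would also leave the read-out this high. Going by these compounds, it is equally open whether the same exchange would give the same result on the differently substituted compound 1 or compound 3.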